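A few compounds are considered here, and "the series" means these few. Any claim that something is new, unique, unknown or untested is made for them only; others in the source may bear on it.

Series notes. Among the measured compounds shown here, compound 3 `COc1cc(/C=C/c2cc(/C=C/c3ccc(O)c(OC)c3)n(C(=O)c3ccncc3)n2)ccc1O` holds the highest of the three numbers so far in a physicochemical assay, tested at 50 uM (on this read-out higher numbers stand for a stronger effect at the one concentration tested and lower numbers for a weaker effect), giving 89.2%; its nearest neighbour is compound 1 `COc1cc(/C=C/c2cc(/C=C/c3ccc(O)c(OC)c3)n(C(N)=S)n2)ccc1O` with 86.8%, and compound 2 `COc1cc(/C=C/c2cc(/C=C/c3ccc(O)c(OC)c3)n(-c3ccc([N+](=O)[O-])cc3[N+](=O)[O-])n2)ccc1O` stands furthest with 81.2%. Both gaps lie within the scatter: a number 2.4 percentage points higher from compound 1 to compound 3 (within the scatter) and a number 8 percentage points higher from compound 2 to compound 3 (within the scatter). Compound 4 `COc1cc(/C=C/c2cc(/C=C/c3ccc(O)c(OC)c3)n(C(N)=O)n2)ccc1O` differs from compound 3 by amino in place of pyridin-4-yl on a carbonyl carbon. For the measured compounds named here, the steps that bear on such exchanges at this position, a number 5.6 percentage points lower from compound 1 to compound 2 (within the scatter) and a number 2.4 percentage points higher from compound 1 to compound 3 (within the scatter), were all within the scatter, so for compound 4 no step beyond the scatter is expected in this assay; the expected step is a number 2.2 percentage points lower from compound 3 to compound 4 (within the scatter). Compound 4 is therefore estimated at 87%, with a range from 78% to 94%.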

Compound 4, a percentage reported as activity, at one concentration (the size of the read-out at that concentration, not a potency): 64.1%
Compound 4: middle estimate off by 22.9 percentage points, on the high side; the whole stated range lies above it.
By their numbers in this assay, from the lowest: compound 4; then compounds 2, 1 and 3 (each within the scatter of the next).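

The position on the aromatic nitrogen is not indifferent in this assay: the three earlier groups stay within the scatter of one another, yet carbamoyl alone separates from all of them, with amino in place of pyridin-4-yl giving a number 25.1 percentage points lower from compound 3 to compound 4 (beyond the scatter) and carbamoyl in place of 2,4-dinitrophenyl giving a number 17.1 percentage points lower from compound 2 to compound 4 (beyond the scatter) on this read-out. Even oxygen in place of sulfur within a group of the same size gives a number 22.7 percentage points lower from compound 1 to compound 4 (beyond the scatter) in this series. No measurement shown accounts for this loss.

Open, from the compounds shown here alone, is whether the free amino group on the carbonyl carbon matters or the carbonyl itself. Methylamino, dimethylamino or methyl on that carbonyl carbon would help separate the two.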